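The compounds below may be only part of what the source reports. "The series", "measured", "known", "first", "only" and "open" are said of these compounds alone.

Among the compounds with values here, in a physicochemical assay for acid dissociation, compound 1 `Cc1c(N2CCCCCC2)nc(C2CC2)nc1N1CC(C)C1` gives 8 and compound 2 `c1c(N2CCCCCC2)nc(C2CC2)nc1N1CCC1` gives 7.4 as the only two numbers so far. Compound 2 therefore stands lowest of the two, and its gap to compound 1 lies beyond the scatter. Within the data shown here, no two measured compounds differ in just one place, so no single structural change has yet been seen on its own.

Compound 3 `CC1CN(c2cc(N3CCCCCC3)nc(C3CC3)n2)C1` still awaits measurement in this assay and differs from compound 2 by methyl in place of hydrogen on a saturated ring carbon in one place, with methyl in place of hydrogen on a saturated ring carbon, so that azetidin-1-yl becomes 3-methylazetidin-1-yl. Compound 1 carries the same 3-methylazetidin-1-yl group, but its core differs as well, so its gap to compound 2 cannot be taken as the size of this step.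

The expected change, a number 0.10 log units higher from compound 2 to compound 3 (within the scatter) in the estimate, is small and upward, and it stays within the scatter. For compound 3 the expected value is 7.5 with an estimated range from 7.2 to 7.9 in this measurement.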

Compound 3, acid dissociation constant: 7.5
For compound 3 middle estimate and measured number coincide at the digits printed; the measured number falls inside the stated range.
By their numbers in this assay, from the lowest: compounds 2 and 3 (each within the scatter of the next); then compound 1.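

In this assay the change from azetidin-1-yl to 3-methylazetidin-1-yl can now be read on its own: methyl in place of hydrogen on a saturated ring carbon of the four-membered ring, two ring bonds from the ring nitrogen, amounts to a number 0.10 log units higher from compound 2 to compound 3 (within the scatter) and so cannot be told apart from repeat measurement. Within the data shown here, the other single change, hydrogen in place of methyl on an aromatic carbon, amounts to a number 0.50 log units lower from compound 1 to compound 3 (beyond the scatter) and is the first step in this set to stand beyond the scatter, so of the two single changes seen here, only the one on the aromatic carbon moves the number measurably. Nothing in hand gives a reason for the size of either step.

The compounds shown leave open whether a different group on the same saturated ring carbon, such as ethyl, hydroxymethyl or an amine, would also stay within the scatter in this assay as methyl does. They also leave open whether chlorine or methoxy on the aromatic carbon would shift the number as methyl does, and whether either step keeps its size on another core.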